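Chlorine beside a Purine Amine: Expected Antiproliferative Effect

The source may hold more compounds than are shown below. What is called first, only, known or untested is meant among the compounds shown, and "the series" means these compounds.

Two measured compounds share a core: compound 1 `CCCCCCC(CCO)n1cnc2c(Cl)ncnc21` and compound 2 `CCCCCCC(CCO)n1cnc2c(Cl)nc(Cl)nc21`. In a functional assay on SW480 cells (Homo sapiens) for antiproliferative activity, read by MTT assay, with a stated time of 48 h (a lower number here means a stronger inhibitor, a higher number a weaker inhibitor), compound 1 gives 16700 nM, and compound 2 gives 12400 nM. The change from compound 1 to compound 2 is chloro in place of hydrogen on an aromatic carbon, and it made a 1.3-fold lower number from compound 1 to compound 2 (0.13 log units; within the scatter). Compound 3 `CCCCCCCC(CCO)n1cnc2c(N)ncnc21` carries a different core; how it differs from compound 1 is not broken down here. In this assay compound 3 reaches only a limit of the assay, > 50000 nM, so no number is known for it. Compound 4 `CCCCCCCC(CCO)n1cnc2c(N)nc(Cl)nc21` has not yet been measured. It differs from compound 3 by chloro in place of hydrogen on an aromatic carbon; this is the same kind of change as that from compound 1 to compound 2, though the surroundings differ, the chlorine entering meta to an amino group in compound 4 but meta to a chloro group in compound 2. The step from compound 3 to compound 4 is expected to be an at least 1.1-fold lower number from compound 3 to compound 4 (0.04 log units; that floor lies within the scatter). That expectation rests on a 1.3-fold lower number from compound 1 to compound 2 (0.13 log units; within the scatter) and on (the limit of > 50000 nM in this assay, at which 1 of the 3 values shown sits). For compound 4 the estimated value in this assay is 45000 nM, between 20000 nM and 100000 nM.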

Compound 4, half-maximal inhibitory concentration: > 50000 nM
Compound 4: no number, only a limit (the forecaster's own chance of this, stated with the estimate: 60%); middle value at least 1.1-fold (0.04 log units) away from the limit.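

Compound 4, like compound 3, gives only a limit of the assay in this assay and not a number, so the size of the step between these two compounds cannot be read: the limit of > 50000 nM in this assay, at which 2 of the 4 values shown sit.

The compounds shown leave open whether chloro in place of hydrogen on an aromatic carbon changes the antiproliferative activity of compound 3 at all.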